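This account rests on a few compounds, and the source may have more. Where it says the series, first, only, none or still open, it means among the compounds named here.

Measured so far:
Compound 1 `CS(=O)(=O)CCCOc1ccc2c(c1)OC(COc1ccc(CCC(=O)O)c(F)c1)CC2` gives 38%.
Compound 2 `COCCOc1ccc2c(c1)OC(COc1ccc(CCC(=O)O)c(F)c1)CC2` gives 36%.
Compound 3 `COc1ccc2c(c1)OC(COc1ccc(CCC(=O)O)c(F)c1)CO2` gives 80%.

In a functional assay on HEK293 cells for agonist activity at Free fatty acid receptor 1 (Homo sapiens), read by fluorescence and calcium flux, with a stated time of 10 min (on this read-out lower numbers stand for smaller maximal responses and higher numbers for larger maximal responses), compound 3 stands highest of the three; compound 1 and compound 2 lie below it by more than the scatter. Compound 4 `O=C(O)CCc1ccc(OCC2COc3ccc(Cl)cc3O2)cc1F` differs from compound 3 by chloro in place of methoxy on an aromatic carbon. Among the measured compounds shown here, the only measured step, a number 2 percentage points lower from compound 1 to compound 2 (within the scatter), concerns a group on a saturated chain rather than on an aromatic carbon, so it does not bear directly on this change and gives no guide to its size or direction. For the measured compounds named here, with no closer precedent, compound 4 is expected to stay close to compound 3, with wide uncertainty, so a step of a number 10 percentage points lower from compound 3 to compound 4 (within the scatter) is estimated. The value expected for compound 4 is 70%, in a range from 45% to 95%.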

Compound 4, largest response reached (Emax), in percent of the reference or control that the assay uses: 50%
The estimate for compound 4 lay 20 percentage points above the measured number; the range from low to high includes it.
By their numbers in this assay, from the lowest: compounds 2 and 1 (each within the scatter of the next); then compound 4; then compound 3.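

In this assay, chloro in place of methoxy on this aromatic carbon gives a number 30 percentage points lower from compound 3 to compound 4 (beyond the scatter) on the same core, so the group at this place clearly matters to the maximal response. The earlier step concerned a saturated chain and could not show this. No measurement here explains why the response changes with this swap. Still open, from the compounds shown here alone, is whether an amine, a nitrile or a longer ether chain at this place would match methoxy or chloro. Going by these compounds, it is also open whether the same swap would give a similar step on the core of compound 1.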